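The source may hold more compounds than are shown below. What is called first, only, known or untested is meant among the compounds shown, and "the series" means these compounds.

Compound 1, `COc1cc(OS(=O)(=O)c2ccc(N3CCN(C)C3=O)cc2)cc(OC)c1OC`, gives 120 nM in a functional assay on MCF7 cells (Homo sapiens) for antiproliferative activity, read by sulforhodamine B assay, with a stated time of 48 h; a higher number here means a weaker inhibitor, a lower number a stronger inhibitor. Compound 2, `CCN1CCN(c2ccc(S(=O)(=O)Oc3cc(OC)c(OC)c(OC)c3)cc2)C1=O`, gives 700 nM in this assay. The change between them is methyl in place of hydrogen on a saturated chain carbon bound to an amide-type nitrogen in a ring, and it produced a 5.8-fold higher number from compound 1 to compound 2 (0.77 log units; beyond the scatter). Compound 3, `CCCN1CCN(c2ccc(S(=O)(=O)Oc3ccccc3C)cc2)C1=O`, gives only a limit in this assay, > 100000 nM, and (the limit of > 100000 nM in this assay, at which 1 of the 3 values shown sits). How the core of compound 3 differs from the core of compound 1 is not broken down here. Compound 4, `CCCN1CCN(c2ccc(S(=O)(=O)Oc3ccccc3CC)cc2)C1=O`, carries methyl in place of hydrogen on a saturated chain carbon bound to an aromatic carbon, the same kind of change as from compound 1 to compound 2, though the place differs: there the methyl enters on a saturated chain carbon bound to an amide-type nitrogen in a ring, here on a saturated chain carbon bound to an aromatic carbon. Because compound 3 already sits at the limit > 100000 nM, compound 4 is expected to give a number no higher from compound 3 to compound 4 (the limit leaves the size open) and is estimated at 100000 nM in this assay.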

Compound 4, half-maximal inhibitory concentration: 2300 nM
For compound 4 the middle estimate is 43-fold (1.64 log units) above the measured one; measured number below the stated range.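

The methyl on the saturated chain carbon bound to an aromatic carbon gave an at least 43-fold lower number from compound 3 to compound 4 (1.63 log units; beyond the scatter), and this kind of change did not carry over from one core to the other in size or direction: the same change on two cores in this assay, a 5.8-fold higher number (0.77 log units; beyond the scatter) from compound 1 to compound 2 and an at least 43-fold lower number (1.63 log units; beyond the scatter) from compound 3 to compound 4, at least 250-fold (2.40 log units) apart, beyond the scatter of two such steps

Compound 3 gives > 100000 nM in this assay, a limit and not a number, which leaves the full size of its step open. The two methyl changes sit at different places on different cores, so the pair does not show whether the place or the core sets the outcome.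

The compounds shown leave open how a longer chain such as butyl would read in place of the ethyl of the 2-ethylphenyl group. They also leave open whether the same methyl change would behave alike on the core of compound 1.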